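The compounds below may be only part of what the source reports. "The series", "measured", "known", "first", "only" and "open" are said of these compounds alone.

Compound 1 `O=C(CSc1c[nH]c2c(Br)cccc12)N(Cc1ccccc1)Cc1ccccc1`: in an ADME assay on HEK-293T cells (Homo sapiens) for cytotoxicity, read by CCK-8 assay, with a stated time of 24 h (a lower number here means that less compound is tolerated, a higher number that more compound is tolerated), compound 1 gives > 100000 nM, which is a limit of the assay.
Compound 2 `CN(Cc1ccccc1)C(=O)CSc1c[nH]c2ccccc12`: in this assay compound 2 gives > 100000 nM, again a limit of the assay.
Compound 3 `O=C(CSc1c[nH]c2ccccc12)N(Cc1ccccc1)Cc1ccccc1`: in this assay compound 3 gives > 100000 nM, also a limit of the assay.

Among the measured compounds shown here, the one structural change that recurs in this set is bromo in place of hydrogen on an aromatic carbon. From compound 3 to compound 1 it yields a step that the two limits leave unreadable from compound 3 to compound 1, since both values sit at the limit of > 100000 nM in this assay, at which 3 of the 3 values shown sit. Compound 2 differs from compound 3 in its core by hydrogen in place of phenyl on a saturated chain carbon bound to an amide-type nitrogen. Compound 4 `CN(Cc1ccccc1)C(=O)CSc1c[nH]c2cccc(Br)c12`, not yet measured, carries the change (bromo in place of hydrogen on an aromatic carbon); its place description matches that of the change from compound 3 to compound 1 word for word, so it is the same change. For compound 4 in this assay the step of a number no higher from compound 2 to compound 4 (the limit leaves the size open) is expected, resting on compound 2 and on (the limit of > 100000 nM in this assay, at which 3 of the 3 values shown sit). The estimate for compound 4 is 100000 nM, between 50000 nM and 300000 nM, and it is most likely that the assay again reports only a limit.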

Compound 4, half-maximal cytotoxic concentration: 25100 nM
Estimate against measurement, compound 4: 4.0-fold (0.60 log units) above, outside the stated range (below it).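

In this assay, bromo in place of hydrogen on an aromatic carbon gives an at least 3.9-fold lower number from compound 2 to compound 4 (0.60 log units; beyond the scatter), which shows that on this one core the change brings a readable drop in the tolerated concentration. With the same change on the core of compound 3, compound 1 gives > 100000 nM, a limit of the assay. The steps among compound 1, compound 2 and compound 3 cannot be read, so the result does not show that the drop carries over to the core of compound 3, and the full size of the drop on the core of compound 2 stays open since compound 2 itself stands at a limit: the limit of > 100000 nM in this assay, at which 3 of the 4 values shown sit.

The compounds shown leave open whether chloro or an amine on the same aromatic carbon would also lower the number in this assay. They also leave open whether a longer chain on the amide-type nitrogen of compound 4 would shift it.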